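A few compounds are considered here, and "the series" means these few. Any claim that something is new, unique, unknown or untested is made for them only; others in the source may bear on it.

Working notes on the series. The shared core carries a variable group on its outer benzene ring. Compound 1 `COc1cccc(OC)c1C(=O)Nc1nnc(-c2ccccc2)s1` has hydrogen there and in a functional assay on the whole organism (integument) for inhibition, with Chilo suppressalis as the target, read by scintillation counting, with a stated time of 72 h, in the presence of a further agent that is not named here (a lower number here means a stronger inhibitor, a higher number a weaker inhibitor), compound 1 gives 282 nM. Compound 2 `COc1cccc(OC)c1C(=O)Nc1nnc(-c2ccc(F)cc2)s1` carries fluoro and gives 89.1 nM. Compound 3 `COc1cccc(OC)c1C(=O)Nc1nnc(-c2ccc([N+](=O)[O-])cc2)s1` carries nitro and gives 269 nM. Compound 2 stands lowest of the three numbers; the nearest is compound 3 and the furthest is compound 1, both beyond the scatter. The two steps that define this position are a 3.2-fold lower number from compound 1 to compound 2 (0.50 log units; beyond the scatter) and a 3.0-fold higher number from compound 2 to compound 3 (0.48 log units; beyond the scatter), while a 1.0-fold lower number from compound 1 to compound 3 (0.02 log units; within the scatter) shows hydrogen and nitro to be indistinguishable.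

Compound 4 `COc1cccc(OC)c1C(=O)Nc1nnc(-c2ccc(C#N)cc2)s1` is not yet measured. Its change from compound 2 is cyano in place of fluoro on an aromatic carbon. For the measured compounds named here, two measured steps bear on it: leaving fluoro for hydrogen cost a 3.2-fold lower number from compound 1 to compound 2 (0.50 log units; beyond the scatter) in reverse, and leaving fluoro for nitro cost a 3.0-fold higher number from compound 2 to compound 3 (0.48 log units; beyond the scatter). Both departures from fluoro gave a modest rise in the number, so a cyano group, again a replacement of fluoro, is expected to give a step of similar size in the same direction. For compound 4 the expected step is a 2.2-fold higher number from compound 2 to compound 4 (0.35 log units; beyond the scatter), which puts the estimate at 200 nM, with a range from 80 nM to 500 nM, reflecting that neither nitro nor hydrogen is a direct model for cyano.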

Compound 4, half-maximal inhibitory concentration: 200 nM
For compound 4 middle estimate and measured number coincide at the digits printed, and the stated range covers the measured number.
By their numbers in this assay, from the lowest: compound 2; then compounds 4, 3 and 1 (each within the scatter of the next).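

With cyano, a third group has been set against fluoro at this position in this assay, and a 2.2-fold higher number from compound 2 to compound 4 (0.35 log units; beyond the scatter) shows the same kind of departure as before. Compound 2 now stands apart, beyond the scatter, from each of the other three compounds, which makes it the strongest inhibitor of the four. Cyano does not separate from the other groups, as nitro and cyano cannot be told apart (a 1.3-fold lower number from compound 3 to compound 4 (0.13 log units; within the scatter)), and neither can hydrogen and cyano (a 1.4-fold lower number from compound 1 to compound 4 (0.15 log units; within the scatter)), so among these compounds the gain belongs to fluoro alone and not to substitution as such, with nitro and cyano both going against any such general reading.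

Going by these compounds, what chloro, bromo, methyl, methoxy or an amine would give at this position stays open, as does whether fluoro keeps its standing at other places on the outer benzene ring. Nothing available accounts for the gap between fluoro and the other three groups.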